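The source may report more compounds than this note shows. Statements on the series, on what has been measured and on what is new or still open speak of the compounds shown alone.

Working notes on the series. The shared core is kept fixed and only the amide end varies. Compound 1 `O=C(c1cccc(Nc2ncc(F)c(Nc3ccc(F)cc3)n2)c1)N1CCCCC1` carries a piperidin-1-yl on the carbonyl carbon, and in a functional assay on KB cells (Homo sapiens) for antiproliferative activity, read by sulforhodamine B assay, with a stated time of 3 days (a lower number here means a stronger inhibitor of growth, a higher number a weaker inhibitor of growth), compound 1 gives 14800 nM. Among the measured compounds shown here, compound 2 `O=C(Nc1cc(Cl)cc(Cl)c1)c1cccc(Nc2ncc(F)c(Nc3ccc(F)cc3)n2)c1` carries (3,5-dichlorophenyl)amino at that carbon instead; in this assay compound 2 gives 20100 nM, the highest of the two numbers so far, with compound 1 nearest to it. For the measured compounds named here, the only measured step, a 1.4-fold higher number from compound 1 to compound 2 (0.13 log units; within the scatter), shows that exchanging the amide substituent left the number essentially where it was.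

Compound 3 `O=C(NCCO)c1cccc(Nc2ncc(F)c(Nc3ccc(F)cc3)n2)c1` is the next member: 2-hydroxyethyl in place of 3,5-dichlorophenyl on an amide-type nitrogen. Its ring leaves the amide nitrogen and a short chain takes its place. Going by the values given here, the one step that bears on this position, from compound 1 to compound 2, was within the scatter, so the amide end has so far not moved this assay. On that thin basis the expected step is a 1.0-fold lower number from compound 2 to compound 3 (0.00 log units; within the scatter), nothing beyond the scatter, although the present change is larger than the earlier one and the range is set wide accordingly. Compound 3 is therefore estimated to give 20000 nM in this assay, between 7000 nM and 60000 nM.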

Compound 3, concentration for 50% growth inhibition: 12400 nM
The estimate for compound 3 lay 1.6-fold (0.21 log units) above the measured number; measured number inside the range.
By their numbers in this assay, from the lowest: compounds 3, 1 and 2 (each within the scatter of the next).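

In this assay, 2-hydroxyethyl on the amide-type nitrogen gives a 1.6-fold lower number from compound 2 to compound 3 (0.21 log units; within the scatter), and (2-hydroxyethyl)amino on the carbonyl carbon gives a 1.2-fold lower number from compound 1 to compound 3 (0.08 log units; within the scatter). The earlier pair compared only ends that carry a ring, whereas compound 3 has no ring at this position and has the hydrogen-bond donor and acceptor counted on 2-hydroxyethyl, yet all the steps among the three compounds remain within the scatter, so ring-bearing and ring-free ends are not separated by this assay in this small set. No supporting measurement is available to explain why these different amide ends give readings within the scatter of one another.

The compounds shown leave open whether an amine or a carboxylic acid at the end of a longer chain on the amide-type nitrogen would give a step beyond the scatter from compound 3, which stands at 12400 nM. They also leave open whether any amide end matters when the rest of the shared core is changed, as only the amide end varies here.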